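Swapping the aryl ring on the sulfonyl sulfur

The compounds below may be only part of what the source reports. "The series", "measured", "known", "first", "only" and "open" are said of these compounds alone.

Compound 1 `CC1CCN(c2c(S(=O)(=O)c3cccc(Cl)c3)cnc3ccc(Cl)cc23)CC1` and compound 2 `CC1CCN(c2c(S(=O)(=O)c3ccc(F)cc3)cnc3ccc(Cl)cc23)CC1` share one core and differ only in the aryl ring attached to the sulfonyl sulfur. In an assay on isolated protein for displacement of a labelled ligand from metabotropic glutamate receptor 5 (Homo sapiens), with a stated time of 60 min, tested at 1 uM (on this read-out lower numbers stand for less inhibition and higher numbers for more inhibition at the one concentration tested (going by the name of the read-out)), compound 1 gives 92%. In this assay, going by the values given here, compound 2 gives 89%, which is the lower of the two numbers measured so far, with compound 1 as its only neighbour. Among the compounds with values here, the one step between them, a number 3 percentage points lower from compound 1 to compound 2 (within the scatter), lies within the scatter, so the two values cannot be told apart.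

Compound 3 `COc1cccc(S(=O)(=O)c2cnc3ccc(Cl)cc3c2N2CCC(C)CC2)c1` has not yet been measured. It differs from compound 2 in a single place: 3-methoxyphenyl in place of 4-fluorophenyl on a sulfonyl sulfur. Within the data shown here, the only measured step that bears on this change is the earlier exchange of one aryl ring for another on the same sulfonyl sulfur, a number 3 percentage points lower from compound 1 to compound 2 (within the scatter), which stayed within the scatter. On that basis no movement beyond the scatter is expected in this assay, and the expected step is a number 1 percentage points lower from compound 2 to compound 3 (within the scatter). Compound 3 is therefore estimated to give 88%, with a range from 75% to 97%.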

Compound 3, a percentage reported as inhibition, at one concentration (the size of the read-out at that concentration, not a potency): 87%
Estimate against measurement, compound 3: 1 percentage points above, within the range that was stated.
By their numbers in this assay, from the lowest: compounds 3, 2 and 1 (each within the scatter of the next).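

The exchange of 4-fluorophenyl for 3-methoxyphenyl on the sulfonyl sulfur gives a number 2 percentage points lower from compound 2 to compound 3 (within the scatter) in this assay, so a ring with one hydrogen-bond acceptor cannot be told apart here from a ring with none. The change of methoxy in place of chloro on an aromatic carbon gives a number 5 percentage points lower from compound 1 to compound 3 (within the scatter), which means that this exchange also leaves the two numbers indistinguishable. Three different aryl groups on the sulfonyl sulfur now give values that cannot be separated in this assay, although this percentage at one concentration is not a potency and could hide differences that would appear in a full concentration series. Nothing shown here explains why these values stay together.

On these data alone, only chloro, fluoro and methoxy appear as substituents on the aryl ring, so it remains open whether an amine or a carboxylic acid on that ring, or a cyclohexyl group in its place, would move the number beyond the scatter. As far as these compounds go, whether the three compounds differ at lower concentrations also remains open.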